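The source may hold more compounds than are shown below. What is called first, only, known or untested is meant among the compounds shown, and "the series" means these compounds.

Measured compounds:
- compound 1, `FC(F)(F)c1ccccc1NC(=S)N/N=C/c1ccc2ccccc2n1`: 20700 nM
- compound 2, `CN(C)C(=S)N/N=C/c1ccc2cccnc2n1`: 630 nM
- compound 3, `NC(=S)N/N=C/c1cc2cccnc2s1`: 100000 nM

In a functional assay on SGC-7901 cells (Homo sapiens) for antiproliferative activity, read by sulforhodamine B assay, with a stated time of 72 h (a higher number here means a weaker inhibitor, a lower number a stronger inhibitor), compound 1 gives 20700 nM. Among the three numbers this is the second highest: compound 3 gives a higher number, 100000 nM, and that gap lies beyond the scatter, while compound 2 gives a much lower number, 630 nM, again beyond the scatter. Among the compounds with values here, none of these three pairs differ in only one place, so no single-change step between measured compounds is available here.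

Compound 4, `S=C(N/N=C/c1ccc2ccccc2n1)Nc1ccccc1Br`, has not yet been measured in this assay. Relative to compound 1 it carries a single change: bromo in place of trifluoromethyl on an aromatic carbon. The change sits on an aromatic carbon of a six-membered aromatic ring of carbon only, ortho to a large group, and the shared core of compound 1 is kept unchanged.

Within the data shown here, no measured pair shows what a change of this kind does in this assay, so the expectation rests on compound 1 alone. The step from compound 1 to compound 4 is expected to be small, most likely within the usual scatter, and in no particular direction: a 1.2-fold lower number from compound 1 to compound 4 (0.06 log units; within the scatter). Compound 4 is therefore estimated at 18000 nM, with a range from 6000 nM to 60000 nM.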

Compound 4, half-maximal inhibitory concentration: > 100000 nM
Compound 4: no number, only a limit; the forecaster's own chance of this, stated with the estimate: 10%; middle value at least 5.5-fold (0.74 log units) from the limit.
By their numbers in this assay, from the lowest: compound 2; then compound 1; then compound 3.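

In this assay compound 4 gives > 100000 nM, which is a limit of the assay and not a number. Bromo in place of trifluoromethyl on an aromatic carbon, ortho to a large group, brings an at least 4.8-fold higher number from compound 1 to compound 4 (0.68 log units; beyond the scatter); this is the first single-change step in the series, and it shows that the substituent at this position is not freely interchangeable, since a swap here moves the reading beyond the scatter. The step can only be read as a lower bound, since the reading of compound 4 ends at the limit: the limit of > 100000 nM in this assay, at which 1 of the 4 values shown sits.

One step at one position leaves open whether the change in the reading follows from the arrival of bromo or the departure of trifluoromethyl, and how a methoxy group, a nitrile or an amine would read at the same place on the shared core. Also open, on these data alone, is whether the same swap would give a similar step with the group placed elsewhere on that six-membered aromatic ring.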